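The source may report more compounds than this note shows. Statements on the series, on what has been measured and on what is new or still open speak of the compounds shown alone.

Working notes on the series. In an ADME assay on HepG2 2.2.15 cells (Homo sapiens) for cytotoxicity, read by CCK-8 assay, with a stated time of 8 days (on this read-out lower numbers stand for higher toxicity in this test and higher numbers for lower toxicity in this test), compound 1 (`COc1ccc(-c2cc(NC(=O)c3ccccc3O)c[nH]c2=O)cc1`) gives > 100000 nM, which is a limit of the assay and not a number. Compound 2 (`COc1ccc(-c2cc(NC(=O)c3cccc(OC)c3O)c[nH]c2=O)cc1`) gives 49200 nM and compound 3 (`Cc1cccc(-c2cc(NC(=O)c3ccccc3O)c[nH]c2=O)c1`) gives 98800 nM, two values within the scatter of each other.

The next step leads to compound 4 (`Cc1cccc(-c2cc(NC(=O)c3ccc(F)cc3O)c[nH]c2=O)c1`). The change from compound 3 is fluoro in place of hydrogen on an aromatic carbon, so that 2-hydroxyphenyl becomes 4-fluoro-2-hydroxyphenyl.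

Among the compounds with values here, two measured steps bear on this. The nearer in kind is an at least 2.0-fold lower number from compound 1 to compound 2 (0.30 log units; that floor lies within the scatter), for methoxy in place of hydrogen on an aromatic carbon. The other is an at least 1.0-fold lower number from compound 1 to compound 3 (0.00 log units; that floor lies within the scatter), for 3-methylphenyl in place of 4-methoxyphenyl on an aromatic carbon. Both start from the limit of compound 1, so each gives only a floor, and both floors lie within the scatter.

With only these floors to go on, and with compound 3 at 98800 nM, no step beyond the scatter is expected in this assay. The estimated change is a 1.4-fold lower number from compound 3 to compound 4 (0.15 log units; within the scatter), and its direction is not firmly expected. For compound 4 the estimate is 70000 nM, with an expected range of 30000 nM to 150000 nM.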

Compound 4, half-maximal cytotoxic concentration: 37200 nM
Compound 4: the middle estimate sits 1.9-fold (0.27 log units) above what was measured; the measured number falls inside the stated range.
By their numbers in this assay, from the lowest: compounds 4, 2 and 3 (each within the scatter of the next, the first and the last beyond it). At a limit, above all of these: compound 1.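

In this assay, the one step with a number at both ends is a 2.7-fold lower number from compound 3 to compound 4 (0.42 log units; beyond the scatter), and it is also the only step shown that lies beyond the scatter, so fluoro at this position, meta to the hydroxy group and para to a large group, goes with a modest shift towards higher toxicity in this test. The steps from the shared parent gave floors and no sizes, since both start from compound 1, whose value is a limit and not a number: the limit of > 100000 nM in this assay, at which 1 of the 4 values shown sits. Compound 4 thus gives the series its first readable size for a single-atom change on the 2-hydroxyphenyl ring, though that size rests on one pair, with the 3-methylphenyl group held constant.

From the compounds shown here alone, whether a chloro, a methyl or an amine at this same position would move the number in the same direction, or by a similar size, stays open. Also open is whether the step from 2-hydroxyphenyl to 4-fluoro-2-hydroxyphenyl carries over to the 4-methoxyphenyl partner of compound 1, and the compounds shown give no reason for the step.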